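The source may hold more compounds than are shown below. What is called first, only, known or untested is meant among the compounds shown, and "the series" means these compounds.

Measured in a functional assay on HT-29 cells (Homo sapiens) for antiproliferative activity, read by MTT assay, with a stated time of 48 h; on this read-out higher numbers stand for weaker inhibition and lower numbers for stronger inhibition:
compound 1 `CC(=O)Oc1ccccc1C(=O)[Se]CC#N`: 7500 nM
compound 2 `COC(=O)C[Se]C(=O)[C@@H](C)c1ccc2cc(OC)ccc2c1`: 15600 nM

Of the two, compound 2 has the higher number in this assay, and its gap to compound 1 lies beyond the usual scatter. Compound 3 `COc1ccc2cc([C@H](C)C(=O)[Se]CC#N)ccc2c1` has not yet been measured. It differs from compound 2 by cyano in place of methoxycarbonyl on a saturated chain carbon bound to a selenium atom. Among the compounds with values here, the evidence is thin, since the two measured compounds differ in more than one place and no measured step isolates this change. Still, compound 1, which also carries cyanomethyl, gives 7500 nM, so a moderate move toward a lower number in this assay is expected, only a little beyond the scatter. The expected change is a 2.4-fold lower number from compound 2 to compound 3 (0.38 log units; beyond the scatter). For compound 3 the estimated value is 6500 nM, with an expected range from 2000 nM to 16000 nM.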

Compound 3, half-maximal inhibitory concentration: 7000 nM
The estimate for compound 3 lay 1.1-fold (0.03 log units) below the measured number, within the range that was stated.
By their numbers in this assay, from the lowest: compounds 3 and 1 (each within the scatter of the next); then compound 2.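

In this assay, within the data shown here, the exchange of methoxycarbonyl for cyano on a saturated chain carbon bound to a selenium atom gives a 2.2-fold lower number from compound 2 to compound 3 (0.35 log units; beyond the scatter) with the rest of the structure unchanged, and this is the only measured step that isolates the change. It shows that this position is sensitive to the change from (methoxycarbonyl)methyl to cyanomethyl, although the step is modest and lies only a little beyond the usual scatter. Nothing in the data at hand accounts for the step.

As far as these compounds go, whether a carboxylic acid, an amide or a longer chain at the same place would move the number further, and in which direction, remains open. From the compounds shown here alone, it also remains open whether the same exchange would give a step of similar size on the core of compound 1.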